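This account rests on a few compounds, and the source may have more. Where it says the series, first, only, none or still open, it means among the compounds named here.

Compound 1 `COc1ccc(/C=N/NC(=O)Nc2ccc(Oc3ccnc(-c4nncn4CCN(C)C)c3)c(F)c2)c(OC)c1OC` gives 7650 nM in a functional assay on U-87MG ATCC cells (Homo sapiens) for cytotoxicity, read by MTT assay, with a stated time of 72 h (a lower number here means a stronger inhibitor, a higher number a weaker inhibitor), and it stands lowest of the two numbers available, with compound 2 `CN(C)CCn1cnnc1-c1cc(Oc2ccc(NC(=O)N/N=C/c3cccc(Cl)c3Cl)cc2F)ccn1` nearest at 13200 nM. Compound 3 `CN(C)CCn1cnnc1-c1cc(Oc2ccc(NC(=O)N/N=C/c3ccc(Cl)cc3)cc2F)ccn1` has not yet been measured in this assay. It differs from compound 1 by 4-chlorophenyl in place of 2,3,4-trimethoxyphenyl on a carbon with a double bond to nitrogen. For the measured compounds named here, the one measured step that bears on this change is a 1.7-fold higher number from compound 1 to compound 2 (0.24 log units; within the scatter), where the 2,3,4-trimethoxyphenyl likewise gave way to a chlorinated phenyl, there 2,3-dichlorophenyl, on the carbon with a double bond to nitrogen, and the number moved only within the scatter. On that basis the expected step is a 1.3-fold higher number from compound 1 to compound 3 (0.12 log units; within the scatter), a shift that would not rise beyond the scatter. Compound 3 is therefore estimated at 10000 nM in this assay, with a plausible range from 4000 nM to 25000 nM.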

Compound 3, half-maximal inhibitory concentration: 1370 nM
For compound 3 the middle estimate is 7.3-fold (0.86 log units) above the measured one; measured number below the stated range.
By their numbers in this assay, from the lowest: compound 3; then compounds 1 and 2 (each within the scatter of the next).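

In this assay, the group on a carbon with a double bond to nitrogen now makes a clear difference, as 4-chlorophenyl gives a 5.6-fold lower number from compound 1 to compound 3 (0.75 log units; beyond the scatter) and a 9.6-fold lower number from compound 2 to compound 3 (0.98 log units; beyond the scatter). Compounds 1 and 2 had stayed within the scatter of each other, so this position showed a response only with the 4-chlorophenyl, and the step from 2,3-dichlorophenyl shows that a chlorinated phenyl alone does not bring the lower number. Nothing available explains why the 4-chlorophenyl stands apart.

The compounds shown leave open whether the lower number depends on the chlorine itself or on where it sits on the ring. A plain phenyl, a 4-fluorophenyl, a 4-methoxyphenyl or a 3-chlorophenyl on the same carbon would bear on that question.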